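Compound 3 to compound 4: an oxiranylmethyl replacement

A few compounds are considered here, and "the series" means these few. Any claim that something is new, unique, unknown or untested is made for them only; others in the source may bear on it.

In a functional assay on Daudi cells (Homo sapiens) for antiproliferative activity (a lower number here means a stronger inhibitor, a higher number a weaker inhibitor), compound 3 `Nc1ncnc2c1c(-c1ccc(Oc3ccccc3)cc1)cn2C[C@H]1CCCN1C(CO)CO` gives 28200 nM, level within the scatter with compound 2 `Nc1ncnc2c1c(-c1ccc(Oc3ccccc3)cc1)cn2C[C@H]1CCCN1C[C@@H](O)CO` at 14400 nM. Both numbers lie above that of compound 1 `Nc1ncnc2c1c(-c1ccc(NC(=O)c3ccccc3)cc1)cn2[C@H]1CCN(C[C@@H]2CO2)C1` at 3180 nM. Compound 4 `Nc1ncnc2c1c(-c1ccc(Oc3ccccc3)cc1)cn2[C@H]1CCN(C[C@@H]2CO2)C1` follows from compound 3 through (1-((oxiran-2-yl)methyl)pyrrolidin-3-yl in place of (1-(2-hydroxy-1-(hydroxymethyl)ethyl)pyrrolidin-2-yl)methyl on an aromatic nitrogen). For the measured compounds named here, the only measured step, a 2.0-fold higher number from compound 2 to compound 3 (0.29 log units; within the scatter), lies within the scatter and touches only the group on the amine nitrogen, so it offers little guidance here. Going by the values given here, no measured step isolates this replacement. The closest evidence is compound 1 at 3180 nM, which carries the entering group but differs elsewhere on the shared core. The expected change is a 5.6-fold lower number from compound 3 to compound 4 (0.75 log units; beyond the scatter) in this assay, a tentative move towards a lower number. For compound 4 the estimated value is 5000 nM, with an expected range of 1500 nM to 18000 nM.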

Compound 4, half-maximal inhibitory concentration: 5480 nM
Estimate against measurement, compound 4: 1.1-fold (0.04 log units) below, and the stated range covers the measured number.
By their numbers in this assay, from the lowest: compounds 1 and 4 (each within the scatter of the next); then compounds 2 and 3 (each within the scatter of the next).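

In this assay, 1-((oxiran-2-yl)methyl)pyrrolidin-3-yl on the aromatic nitrogen gives a 5.1-fold lower number from compound 3 to compound 4 (0.71 log units; beyond the scatter) and a 2.6-fold lower number from compound 2 to compound 4 (0.42 log units; beyond the scatter), both beyond the scatter, whereas the earlier change on the amine nitrogen alone stayed within it. With that group held, phenoxy in place of benzamido on an aromatic carbon gives a 1.7-fold higher number from compound 1 to compound 4 (0.24 log units; within the scatter), also within the scatter. No measurement shown accounts for these steps.

The entering group alters the ring and its nitrogen substituent together, and the compounds shown do not separate the two. From the compounds shown here alone, how a plain methyl on the pyrrolidin-3-yl nitrogen would read remains open.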